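Shortening the Side Chain Beneath a Cytotoxicity Limit

The compounds below may be only part of what the source reports. "The series", "measured", "known", "first", "only" and "open" are said of these compounds alone.

compound 1, `CCCCNc1nc(N)nc2c1ncn2/C=C1/CC1(CO)CO`: > 20000 nM
compound 2, `Nc1nc(NC2CCCC2)c2ncn(/C=C3/CC3(CO)CO)c2n1`: > 20000 nM
compound 3, `CC(C)Sc1nc(N)nc2c1ncn2/C=C1/CC1(CO)CO`: 94000 nM

In an ADME assay on CCRF-HSB-2 cells (Homo sapiens) for cytotoxicity, with a stated time of 7 days (on this read-out lower numbers stand for higher toxicity in this test and higher numbers for lower toxicity in this test), compound 1 reaches only a limit of the assay, > 20000 nM, not a number. Compound 2 also stops at a limit in this assay. Compound 3 alone gives a measured number in this assay. Going by the values given here, of the steps among them, a step that the two limits leave unreadable from compound 1 to compound 2, a step that the limit leaves unreadable from compound 1 to compound 3 and a step that the limit leaves unreadable from compound 2 to compound 3 are all left unreadable by these limits, and the limit of > 20000 nM in this assay, at which 2 of the 3 values shown sit, is the only evidence the three values give. Compound 4, `CNc1nc(N)nc2c1ncn2/C=C1/CC1(CO)CO`, differs from compound 1 by hydrogen in place of propyl on a saturated chain carbon bound to a nitrogen on an aromatic ring. No measured step bears on this change, and none of the shown steps has a readable size. Compound 4 is therefore expected to remain near the limit, at an estimated 30000 nM, with a range from 20000 nM to 100000 nM. The step that the limit leaves unreadable from compound 1 to compound 4 is expected to be no more than scatter, and most likely the assay will again report only a limit.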

Compound 4, half-maximal cytotoxic concentration: > 20000 nM
Compound 4 gave a limit, no number (the forecaster's own chance of this, stated with the estimate: 80%); the middle value does not contradict the limit.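

Compound 4 gives only a limit in this assay, not a number, and its steps to compound 1, compound 2 and compound 3 cannot be read. The compounds shown leave open whether butylamino to methylamino changes cytotoxicity at all, since compound 1 and compound 4 both stop at a limit.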